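Meta substituent swap in the thioether series

The compounds below may be only part of what the source reports. "The series", "measured", "known", "first", "only" and "open" are said of these compounds alone.

Compounds measured so far:
compound 1 `C#CCNC1CCc2c(SCc3cccc(F)c3)cccc21`, 1480 nM
compound 2 `C#CCNC1CCc2c(SCCc3cccc(Br)c3)cccc21`, 30500 nM
compound 3 `C#CCNC1CCc2c(SCCc3ccc(Cl)c(Cl)c3)cccc21`, 3850 nM

In an assay on isolated protein for inhibition of Amine oxidase [flavin-containing] B (Homo sapiens) (on this read-out higher numbers stand for weaker inhibition and lower numbers for stronger inhibition), compound 1 gives the lowest of the three numbers; compound 3 lies nearer to it and compound 2 furthest away, with both gaps beyond the scatter. For the measured compounds named here, the only single-site step recorded within the set, a 7.9-fold lower number from compound 2 to compound 3 (0.90 log units; beyond the scatter), concerns the aryl substituents on the longer chain and does not touch the change considered here.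

Compound 4 `C#CCNC1CCc2c(SCc3cccc(OC)c3)cccc21` differs from compound 1 by methoxy in place of fluoro on an aromatic carbon. Going by the values given here, no measured pair shows this exchange, nor any change at that ring position on the one-carbon chain, so the size of the step in this assay can be argued only weakly. Among the compounds with values here, with a single measurement behind compound 1 and no comparable step to lean on, a small change is expected for compound 4, of either direction, with a wide range: the estimate for compound 4 is 2500 nM, between 700 nM and 9000 nM. That corresponds to an expected step of a 1.7-fold higher number from compound 1 to compound 4 (0.23 log units; within the scatter).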

Compound 4, half-maximal inhibitory concentration: 3190 nM
Compound 4: middle estimate off by 1.3-fold (0.11 log units), on the low side; measured number inside the range.
By their numbers in this assay, from the lowest: compound 1; then compounds 4 and 3 (each within the scatter of the next); then compound 2.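

In this assay, for the compounds shown here, the exchange of methoxy for fluoro gives a 2.2-fold higher number from compound 1 to compound 4 (0.33 log units; beyond the scatter) and is the first reading at this ring position on the one-carbon chain. The position therefore responds to this change, but the step is modest, and replacing one heavy atom with two leaves compound 4 measurable on the same read-out. This single pair cannot separate the extra heavy atom from the added hydrogen-bond acceptor, and nothing available speaks to the reason for the step.

Still open, from the compounds shown here alone, is how other groups at this position would read, such as a hydroxyl, an amine or a carboxylic acid, and whether the order of fluoro and methoxy would hold there. Also open, going by these compounds, is whether the same exchange on the longer chain would give a step of similar size.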